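The source may report more compounds than this note shows. Statements on the series, on what has been measured and on what is new or still open speak of the compounds shown alone.

Measured so far:
compound 1 `COC(CCn1cnc2c(NCc3ccc(C(=O)Nc4ccccc4N)cc3)nc(Cl)nc21)OC` — 34.2%
compound 2 `Nc1ccccc1NC(=O)c1ccc(Cn2cnc3c(NCc4ccccc4)nc(Cl)nc32)cc1` — 62.8%
compound 3 `CCCCn1cnc2c(Nc3ccccc3)nc(NCOCc3ccc(/C=C/C(=O)Nc4ccccc4N)cc3)nc21` — 59.3%

Of the compounds shown here, three have been tested in a functional assay on HepG2 cells (Homo sapiens) for antiproliferative activity, read by CCK-8 assay, with a stated time of 72 h, tested at 8 uM; a higher number here means a stronger effect of the compound at the concentration tested, a lower number a weaker effect. Compound 2 gives the highest of the three numbers, at 62.8%. Compound 3 stands nearest to it, with 59.3%, a gap that lies within the scatter of this kind of measurement, so the two cannot be told apart. Compound 1 stands furthest away, at 34.2%, a gap that lies beyond the scatter.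

Compound 4 `CN1CCN(c2nc(Cl)nc3c2ncn3Cc2ccc(C(=O)Nc3ccccc3N)cc2)CC1` has not yet been measured in this assay. It differs from compound 2 in one place: 4-methylpiperazin-1-yl in place of benzylamino on an aromatic carbon. Among the measured compounds shown here, no step between two measured compounds with this same change is available, so there is nothing to read the size of this step from directly.

The expectation is therefore cautious. Compound 4 is expected to give 50% in this assay, within a range from 30% to 68%. This estimate means a step from compound 2 to compound 4 of a number 12.8 percentage points lower from compound 2 to compound 4 (beyond the scatter), a moderate fall that may well sit inside the scatter.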

Compound 4, a percentage reported as inhibition, at one concentration (the size of the read-out at that concentration, not a potency): 75%
For compound 4 the middle estimate is 25 percentage points below the measured one; the whole stated range lies below it.
By their numbers in this assay, from the lowest: compound 1; then compounds 3 and 2 (each within the scatter of the next); then compound 4.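

In this assay, among the compounds shown here, placing 4-methylpiperazin-1-yl instead of benzylamino on this aromatic carbon, next to the ring nitrogen, gives a number 12.2 percentage points higher from compound 2 to compound 4 (beyond the scatter), the first direct reading of a change at this place. The effect here therefore does not depend on keeping benzylamino, with its six-membered aromatic ring of carbon only and its hydrogen-bond donor: a non-aromatic ring with 2 hetero atoms and 0 hydrogen-bond donors takes its place without any loss. No measurement of a property of either group bears on this step.

One step cannot separate the roles of the ring, its second nitrogen and its methyl group; piperazin-1-yl without the methyl, morpholin-4-yl or a plain dimethylamino group at this carbon would help to do so. On these data alone, whether the change gives a similar step with a different group on the rest of the molecule also stays open.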